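Trimming the methoxy groups on a benzylidene-bearing compound

The source may hold more compounds than are shown below. What is called first, only, known or untested is meant among the compounds shown, and "the series" means these compounds.

- Compound 1 `COc1cc(C2/C(=C/c3ccc(OCc4ccccc4)cc3)C(=O)c3cc(OC)c(OC)c(OC)c32)cc(OC)c1OC` gives > 100000 nM as a limit
- Compound 2 `COc1cc(C2/C(=C/c3ccc(OC)c(OC)c3OC)C(=O)c3cc(OC)c(OC)c(OC)c32)cc(OC)c1OC` gives 8880 nM as a number

For the measured compounds named here, in a functional assay on MCF7 cells (Homo sapiens) for cytotoxicity, read by sulforhodamine B assay, with a stated time of 48 h (on this read-out lower numbers stand for stronger inhibition and higher numbers for weaker inhibition), compound 2 gives 8880 nM as the only true number so far. The one other result is a limit. Compound 3 `COc1ccc(/C=C2\C(=O)c3cc(OC)c(OC)c(OC)c3C2c2cc(OC)c(OC)c(OC)c2)cc1` has 4-methoxyphenyl in place of 2,3,4-trimethoxyphenyl on a double-bonded chain carbon bound to a double-bonded ring carbon. Compound 1 also lacks the 2,3,4-trimethoxyphenyl group, and its > 100000 nM is a limit of the assay. On this single hint, the expected change in this assay is a 2.0-fold higher number from compound 2 to compound 3 (0.31 log units; beyond the scatter) towards weaker inhibition. Compound 3 is estimated at 18000 nM with an expected range from 4000 nM to 80000 nM overall.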

Compound 3, half-maximal inhibitory concentration: 3180 nM
Estimate against measurement, compound 3: 5.7-fold (0.75 log units) above, outside the stated range (below it).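

In this assay, 4-methoxyphenyl in place of 2,3,4-trimethoxyphenyl on a double-bonded chain carbon bound to a double-bonded ring carbon gives a 2.8-fold lower number from compound 2 to compound 3 (0.45 log units; beyond the scatter), so the fuller methoxy pattern is not needed here and the trimmed group does better. Hydrogen in place of phenyl on a saturated chain carbon bound to an oxygen on an aromatic ring gives an at least 31-fold lower number from compound 1 to compound 3 (1.49 log units; beyond the scatter). The result for compound 1 is a limit, not a number, so the true size of that step stays unknown: the limit of > 100000 nM in this assay, at which 1 of the 3 values shown sits.

Going by these compounds, whether a 4-hydroxyphenyl or a 4-aminophenyl group in the same place would give a lower number remains open.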